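A few compounds are considered here, and "the series" means these few. Any claim that something is new, unique, unknown or untested is made for them only; others in the source may bear on it.

In a functional assay on HeLa cells (Homo sapiens) for inhibition, read by CCK-8 assay, with a stated time of 48 h (a lower number here means a stronger inhibitor, a higher number a weaker inhibitor), compound 1 (`COc1ccc(Oc2ccccc2-c2ccsc2S(=O)(=O)NCCNC(=S)Nc2cc(C(F)(F)F)cc(C(F)(F)F)c2)cc1OC`) gives 6400 nM and compound 2 (`COc1ccc(Oc2ccc(C(C)C)cc2-c2ccsc2S(=O)(=O)NCCNC(=S)Nc2cc(C(F)(F)F)cc(C(F)(F)F)c2)cc1OC`) gives 8300 nM, so compound 2 stands level with compound 1, the step being a 1.3-fold higher number from compound 1 to compound 2 (0.11 log units; within the scatter). Compound 3 (`CC(C)c1ccc(Oc2ccc(O)c(O)c2)c(-c2ccsc2S(=O)(=O)NCCNC(=S)Nc2cc(C(F)(F)F)cc(C(F)(F)F)c2)c1`) carries 3,4-dihydroxyphenyl in place of 3,4-dimethoxyphenyl on an oxygen on an aromatic ring. Within the data shown here, the one measured step is an isopropyl change elsewhere, so no measured pair tests this replacement directly. A moderate move to a lower number in this assay is expected, held loosely. The expected change is a 2.4-fold lower number from compound 2 to compound 3 (0.38 log units; beyond the scatter). For compound 3 the estimated value is 3500 nM, with an expected range of 1000 nM to 10000 nM.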

Compound 3, half-maximal inhibitory concentration: > 20000 nM
Compound 3 ended at the assay's limit; the forecaster's own chance of this, stated with the estimate: 3%; middle value at least 5.7-fold (0.75 log units) away from the limit.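

In this assay, 3,4-dihydroxyphenyl in place of 3,4-dimethoxyphenyl on this oxygen gives an at least 2.4-fold higher number from compound 2 to compound 3 (0.38 log units; beyond the scatter). Among these compounds, this is the first step printed as beyond the scatter, so this position responds to the change, whereas the isopropyl step elsewhere did not. The value of compound 3 is a limit and not a number, so the full size of the step stays unknown: the limit of > 20000 nM in this assay, at which 1 of the 3 values shown sits.

Open, on these data alone, is whether the loss needs both hydroxyl groups. Also open, as far as these compounds go, is how a single methoxy, an amine or a carboxylic acid on this ring would read in this assay.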